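The source may report more compounds than this note shows. Statements on the series, on what has been measured and on what is new or still open speak of the compounds shown alone.

Of the compounds shown here, three sharing one core have been tested in an assay on isolated protein for inhibition of carbonic anhydrase 4 (Homo sapiens), read by stopped-flow, with a stated time of 15 min; a higher number here means a weaker inhibitor, a lower number a stronger inhibitor. Compound 1 `O=C1c2cccc(O)c2C(=O)C1(O)O` carries a hydroxy group on its aromatic ring; in this assay compound 1 reaches only the limit of > 100000 nM. Compound 2 `Cc1cccc2c1C(=O)C(O)(O)C2=O` has a methyl group in that place, and compound 2 likewise reaches only the limit of > 100000 nM. Compound 3 `O=C1c2cccc(Br)c2C(=O)C1(O)O` carries a bromo group there, and compound 3 too gives only the limit of > 100000 nM. Because all three sit at the limit of > 100000 nM in this assay, at which 3 of the 3 values shown sit, none of the steps between them can be read: a step that the two limits leave unreadable from compound 1 to compound 2, a step that the two limits leave unreadable from compound 1 to compound 3 and a step that the two limits leave unreadable from compound 2 to compound 3 are all of unreadable size. Compound 3 therefore stands exactly where every measured compound stands, at the limit, with no number that would set it apart.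

Compound 4 `O=C1c2cc(Br)cc(Br)c2C(=O)C1(O)O` differs from compound 3 by bromo in place of hydrogen on an aromatic carbon. The three measured steps bear on this change only in showing that changing one group on this ring has so far never moved a compound off the limit, so no step beyond the scatter in this assay is expected in either direction. Compound 4 is estimated at 100000 nM, within 30000 nM to 300000 nM, which means an expected step of a number no higher from compound 3 to compound 4 (the limit leaves the size open).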

Compound 4, inhibition constant: > 100000 nM
Compound 4: a limit, no number; the forecaster's own chance of this, stated with the estimate: 80%; the middle value lies on the limit itself.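

For the compounds shown here, compound 3 and compound 4 both end at a limit rather than a number, so no step between them can be read, and the same is true across the whole set: the limit of > 100000 nM in this assay, at which 4 of the 4 values shown sit. The compounds shown leave open how strongly any of them actually inhibits the enzyme, and which change to the shared core would give a readable number.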